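From dicyanomethyl to 2,2,2-trifluoroethyl on a saturated chain carbon

The source may report more compounds than this note shows. Statements on the series, on what has been measured and on what is new or still open speak of the compounds shown alone.

Three compounds have been measured in an ADME assay on microsomes from liver (Homo sapiens) for metabolic stability, read by LC-MS, using NADPH, tested at 3 uM (on this read-out higher numbers stand for a longer-lived compound and lower numbers for a shorter-lived compound), so far:
Compound 1 `Cc1ccc2c(C(c3cccs3)C(C#N)C#N)c(-c3ccccc3)[nH]c2c1` gives 0.52 h
Compound 2 `O=C(C(c1ccccc1)c1c(-c2ccccc2)[nH]c2ccccc12)C(F)(F)F` gives 0.852 h
Compound 3 `OC(C(c1ccccc1)c1c(-c2ccccc2)[nH]c2ccccc12)C(F)(F)F` gives 0.657 h

Compound 1 at 0.52 h sits within the scatter of both compound 2 and compound 3, so this assay sets no order among the three. The next compound to be measured is compound 4 `Cc1ccc2c(C(CC(F)(F)F)c3cccs3)c(-c3ccccc3)[nH]c2c1` and it keeps the core of compound 1. The difference is 2,2,2-trifluoroethyl in place of dicyanomethyl on a saturated chain carbon bound to two aromatic carbons and consists of 2,2,2-trifluoroethyl in place of dicyanomethyl on a saturated chain carbon bound to two aromatic carbons.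

For the measured compounds named here, no measured step makes this exact exchange. Going by the values given here, the nearest evidence is the one measured step at such a carbon, which is a 1.3-fold lower number from compound 2 to compound 3 (0.11 log units; within the scatter) and stays within the scatter. It involves other groups, so it offers only indirect guidance. The three measured values also lie within the scatter of one another, although their structures differ at that carbon and elsewhere. Nothing here points to a large shift in either direction. The expected change is a 1.1-fold higher number from compound 1 to compound 4 (0.02 log units; within the scatter) and so nothing beyond the scatter is anticipated. For compound 4 the estimated half-life is 0.55 h in this assay with an expected range from 0.25 h to 1.2 h for the measurement.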

Compound 4, half-life: 1.8 h
Beside the measured number, compound 4's estimate is 3.3-fold (0.51 log units) below it, and the stated range ends below it.
By their numbers in this assay, from the lowest: compounds 1, 3 and 2 (each within the scatter of the next); then compound 4.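

In this assay, for the compounds shown here, the exchange on a saturated chain carbon bound to two aromatic carbons gives a 3.5-fold higher number from compound 1 to compound 4 (0.54 log units; beyond the scatter) and is the first step in the set to go beyond the scatter. The only earlier step at such a carbon, a 1.3-fold lower number from compound 2 to compound 3 (0.11 log units; within the scatter), stayed within it, so the earlier compounds had not shown that the group at this carbon can shift the half-life measurably. With the core of compound 1 held fixed, 2,2,2-trifluoroethyl gives the longer half-life and dicyanomethyl the shorter, but nothing available explains the difference.

The compounds shown leave open whether an ethyl or a cyanomethyl group on this carbon would give a half-life closer to that of compound 1 or to that of compound 4, and so whether the shift goes with the fluorine atoms entering or the nitrile groups leaving. They also leave open whether the same exchange would give a step of this size on the core of compound 2, as the change is seen here in a single pair.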